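From quinolin-3-yl to quinolin-6-yl in HeLa cells

This account rests on a few compounds, and the source may have more. Where it says the series, first, only, none or still open, it means among the compounds named here.

Compound 1 `COc1ccc(-c2nc3ccccn3c2C(=O)/C=C\Nc2ccc3ncccc3c2)cc1` gives 4850 nM
Compound 2 `O=C(/C=C\Nc1ccc2[nH]ccc2c1)c1c(-c2ccc(Cl)cc2)nc2ccccn12` gives 3240 nM
Compound 3 `O=C(/C=C\Nc1cnc2ccccc2c1)c1c(-c2ccc(Cl)cc2)nc2ccccn12` gives 3720 nM
Compound 4 `O=C(/C=C\Nc1ccc2ncccc2c1)c1c(-c2ccc(Cl)cc2)nc2ccccn12` has not yet been measured

In a functional assay on HeLa cells (Homo sapiens) for cytotoxicity, read by MTT assay, with a stated time of 48 h (on this read-out lower numbers stand for stronger inhibition and higher numbers for weaker inhibition), compound 3 gives 3720 nM and so lies within the usual scatter of both compound 2 and compound 1, which leaves no firm ranking around it.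

Compound 4 has the same atoms as compound 3, joined differently (quinolin-6-yl in place of quinolin-3-yl on an amine nitrogen), with quinolin-6-yl in place of quinolin-3-yl on an amine nitrogen. Going by the values given here, no measured pair shows this exact swap. The nearest guide is another change on an amine nitrogen, quinolin-3-yl in place of 1H-indol-5-yl, which gave a 1.1-fold higher number from compound 2 to compound 3 (0.06 log units; within the scatter) as its measured step. Compound 1 also carries quinolin-6-yl, though with another difference elsewhere in the structure, and gives 4850 nM within the scatter of compound 3.

On that evidence the estimated step is a 1.0-fold higher number from compound 3 to compound 4 (0.01 log units; within the scatter) and nothing beyond the scatter is expected. In this assay the estimated value for compound 4 is 3800 nM with 1900 nM to 7000 nM as its expected range.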

Compound 4, half-maximal inhibitory concentration: 16400 nM
The estimate for compound 4 lay 4.3-fold (0.64 log units) below the measured number; measured number outside the range, above it.
By their numbers in this assay, from the lowest: compounds 2, 3 and 1 (each within the scatter of the next); then compound 4.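

In this assay the two quinoline compounds carry the same atoms and differ only in how the ring is joined to the amine nitrogen, yet that change alone gives a clear shift (a 4.4-fold higher number from compound 3 to compound 4 (0.64 log units; beyond the scatter)). The earlier swap on this nitrogen stayed within the scatter (a 1.1-fold higher number from compound 2 to compound 3 (0.06 log units; within the scatter)), so the attachment point of the ring matters here in a way that step could not show. Compound 4 also stands clear of the indole compound (a 5.1-fold higher number from compound 2 to compound 4 (0.70 log units; beyond the scatter)), and with quinolin-6-yl held fixed, the change on the aromatic carbon from methoxy to chloro moves the number as well (a 3.4-fold higher number from compound 1 to compound 4 (0.53 log units; beyond the scatter)), so the group on that carbon also counts when this ring is present.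

The data offer no measurement that explains either shift.

From the compounds shown here alone, it remains open whether quinolin-3-yl would respond in the same way to chloro and methoxy on that aromatic carbon, and how a fluoro or trifluoromethyl group there would behave alongside quinolin-6-yl.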